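The source may report more compounds than this note shows. Statements on the series, on what has been measured and on what is new or still open speak of the compounds shown alone.

Three compounds share one core and differ only at a nitrogen on an aromatic ring. Compound 1 `Fc1ccc(-c2nn3ccc(NC4CCCC4)cc3c2-c2ccnc(NC3CCCC3)n2)cc1` carries a cyclopentyl there, and in an ADME assay on Vero cells (Chlorocebus sabaeus) for cytotoxicity (on this read-out higher numbers stand for lower toxicity in this test and lower numbers for higher toxicity in this test), compound 1 gives 18000 nM. Compound 2 `Nc1ccn2nc(-c3ccc(F)cc3)c(-c3ccnc(NC4CCCC4)n3)c2c1` has hydrogen at that nitrogen, and in this assay compound 2 gives 20000 nM. Compound 3 `COCCNc1ccn2nc(-c3ccc(F)cc3)c(-c3ccnc(NC4CCCC4)n3)c2c1` carries a 2-methoxyethyl at the same place. In this assay compound 3 reaches only a limit of the assay, > 40000 nM, so for compound 3 only a floor is known; this is the limit of > 40000 nM in this assay, at which 1 of the 3 values shown sits. The step of an at least 2.2-fold higher number from compound 1 to compound 3 (0.34 log units; beyond the scatter) and the step of an at least 2.0-fold higher number from compound 2 to compound 3 (0.30 log units; that floor lies within the scatter) both run up to that floor. Compound 4 `CC(C)Nc1ccn2nc(-c3ccc(F)cc3)c(-c3ccnc(NC4CCCC4)n3)c2c1` differs from compound 3 by isopropyl in place of 2-methoxyethyl on a nitrogen on an aromatic ring. Isopropyl, like the cyclopentyl of compound 1, carries no hydrogen-bond acceptor, and compound 1 sits at 18000 nM, so the number for compound 4 is expected to fall back somewhat, with an estimated step of an at least 1.6-fold lower number from compound 3 to compound 4 (0.20 log units; that floor lies within the scatter). Compound 4 is therefore estimated at 25000 nM, with a range from 12000 nM to 50000 nM.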

Compound 4, half-maximal cytotoxic concentration: > 40000 nM
Compound 4 ended at the assay's limit; the forecaster's own chance of this, stated with the estimate: 35%; middle value at least 1.6-fold (0.20 log units) from the limit.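

In this assay, compound 4 stands at a limit of the assay and not at a number, as compound 3 does: the limit of > 40000 nM in this assay, at which 2 of the 4 values shown sit. The 2-methoxyethyl hydrogen-bond acceptor is therefore not required to reach that limit, as isopropyl has none, and the step between compound 3 and compound 4 cannot be read. The result shows an at least 2.0-fold higher number from compound 2 to compound 4 (0.30 log units; that floor lies within the scatter) and an at least 2.2-fold higher number from compound 1 to compound 4 (0.34 log units; beyond the scatter), so having no hydrogen-bond acceptor at this place does not by itself put a compound at the level of compound 1.

Going by these compounds, the true values of compound 3 and compound 4 stay unknown, so the two cannot be ordered. On these data alone, it also remains open whether an amine, a carboxylic acid or a longer chain on this nitrogen would stay at the limit.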